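This account rests on a few compounds, and the source may have more. Where it says the series, first, only, none or still open, it means among the compounds named here.

Measured so far:
compound 1 `CC(=O)Oc1ccccc1C(=O)O[C@H]1CO[C@H]2[C@@H]1OC[C@H]2OC(=O)c1cccc(O)c1` — 0.0183 h
compound 2 `CCCCC(=O)O[C@@H]1CO[C@H]2[C@@H]1OC[C@@H]2OC(=O)c1ccccc1OC(C)=O` — 0.0198 h
compound 3 `CC(=O)Oc1ccccc1C(=O)O[C@H]1CO[C@H]2[C@@H]1OC[C@H]2OC(=O)c1ccccc1C` — 0.035 h

In an ADME assay on a cell-free system (plasma, Homo sapiens) for metabolic stability, with Plasma (Rattus norvegicus) as the target, read by HPLC, at pH 7.4 (on this read-out lower numbers stand for a shorter-lived compound and higher numbers for a longer-lived compound), compound 1 gives the lowest of the three numbers; its neighbours lie within the scatter, a 1.1-fold higher number from compound 1 to compound 2 (0.03 log units; within the scatter) and a 1.9-fold higher number from compound 1 to compound 3 (0.28 log units; within the scatter), and a 1.8-fold higher number from compound 2 to compound 3 (0.25 log units; within the scatter) likewise. Compound 4 `CC(=O)Oc1ccccc1C(=O)O[C@H]1CO[C@H]2[C@@H]1OC[C@H]2O[N+](=O)[O-]` is the untested member. It differs from compound 1 by nitro in place of (3-hydroxyphenyl)carbonyl on an oxygen on a saturated carbon. Going by the values given here, the measured steps all exchange the group on that same carbonyl carbon and none left the scatter, so they bear on this change only loosely: the exchange in compound 4 removes the carbonyl entirely, which no measured pair does. With no step beyond the scatter on this side of the shared core, a step within the scatter, a 1.4-fold higher number from compound 1 to compound 4 (0.14 log units; within the scatter), is expected. Compound 4 is estimated at 0.025 h, range 0.012 h to 0.06 h.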

Compound 4, half-life: 0.0144 h
Compound 4: the middle estimate sits 1.7-fold (0.24 log units) above what was measured, within the range that was stated.
By their numbers in this assay, from the lowest: compounds 4, 1, 2 and 3 (each within the scatter of the next, the first and the last beyond it).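

In this assay, nitro on this oxygen stays within the scatter of (3-hydroxyphenyl)carbonyl (a 1.3-fold lower number from compound 1 to compound 4 (0.10 log units; within the scatter)) and of butylcarbonyl (a 1.4-fold lower number from compound 2 to compound 4 (0.14 log units; within the scatter)), so losing the carbonyl at this position opens no clear gap from these two esters. Only (2-methylphenyl)carbonyl stands apart from nitro (a 2.4-fold lower number from compound 3 to compound 4 (0.39 log units; beyond the scatter)), a modest step and the first beyond the scatter in the series. No measurement available here accounts for this gap. The compounds shown leave open how an ether or a carbamate on this oxygen would compare with nitro and the esters.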